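A few compounds are considered here, and "the series" means these few. Any claim that something is new, unique, unknown or untested is made for them only; others in the source may bear on it.

Two related compounds have been tested so far. Compound 1 `O=c1[nH]c(=O)n([C@@H]2O[C@H](COP(=O)(O)O)[C@@H](O)[C@H]2O)cc1Br` is the open-chain phosphate carrying a bromo group on the six-membered aromatic ring, and in a functional assay on L1210 cells (Mus musculus) (a higher number here means a weaker inhibitor, a lower number a stronger inhibitor), compound 1 gives 385 ug/mL. Compound 2 `O=c1[nH]c(=O)n([C@@H]2O[C@@H]3COP(=O)(O)O[C@H]3[C@H]2O)cc1I` closes the phosphate into a second ring and carries an iodo group in the same place; in this assay compound 2 gives 315 ug/mL. Neither number marks a strong inhibitor, and the two values lie within the usual scatter of each other, so nothing separates compound 1 from compound 2 on what has been measured.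

Compound 3 `O=c1[nH]c(=O)n([C@@H]2O[C@@H]3COP(=O)(O)O[C@H]3[C@H]2O)cc1Cl` keeps the core of compound 2 and changes only the halogen: chloro in place of iodo on an aromatic carbon. Among the measured compounds shown here, no measured pair shows what this exchange does in this assay, and the bromo compound 1 and the iodo compound 2 sit at about the same number. The expectation for compound 3 is therefore a step of no real size in either direction, so that the estimated change a 1.1-fold higher number from compound 2 to compound 3 (0.05 log units; within the scatter) stays within the scatter. For compound 3 the expected value is 350 ug/mL, with a range from 150 ug/mL to 800 ug/mL.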

Compound 3, concentration for 50% inhibition: > 1000 ug/mL
Compound 3 ended at the assay's limit; the forecaster's own chance of this, stated with the estimate: 10%; middle value at least 2.8-fold (0.45 log units) from the limit.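

On the shared core, the halogen on this aromatic carbon matters in this assay: chloro in place of iodo gives an at least 3.1-fold higher number from compound 2 to compound 3 (0.50 log units; beyond the scatter). Compound 3 stands at a limit of the assay and not at a number: the limit of > 1000 ug/mL in this assay, at which 1 of the 3 values shown sits. This is the only exchange of a single group among the compounds shown, and it reads beyond the scatter, whereas compound 1 and compound 2 differ in two places at once and so could not show what the halogen alone does.

Going by these compounds, it remains open how a bromo group would read on the core with the phosphate closed into a second ring, and whether it would fall nearer to iodo or to chloro; compound 1 carries bromo, but its open-chain phosphate means that its halogen and its phosphate cannot be told apart. Also open, on these data alone, are the true size of the step to compound 3 and how a fluoro group, a methyl group or an amine would read at this same place.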